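From hexyloxy to hept-1-en-1-yl on the shared core

A few compounds are considered here, and "the series" means these few. Any claim that something is new, unique, unknown or untested is made for them only; others in the source may bear on it.

In a functional assay (trachea) with Cavia porcellus as the target, in the presence of a further agent that is not named here (on this read-out lower numbers stand for an effect already at smaller amounts and higher numbers for an effect only at larger amounts of compound), compound 1 `CCCCCCCc1ccc(C/C=C/[C@H](SCC(NC(=O)CCC(N)C(=O)O)C(=O)NCC(=O)O)[C@H](O)CCCC(=O)O)cc1` gives 74.5 nM, compound 2 `CCCCCCCc1ccccc1C/C=C/[C@H](SCC(NC(=O)CCC(N)C(=O)O)C(=O)NCC(=O)O)[C@H](O)CCCC(=O)O` gives 18400 nM and compound 3 `CCCCCCOc1ccc(C/C=C/[C@H](SCC(NC(=O)CCC(N)C(=O)O)C(=O)NCC(=O)O)[C@H](O)CCCC(=O)O)cc1` gives 256 nM, the second highest of the three numbers. Compound 4 `CCCCC/C=C/c1ccc(C/C=C/[C@H](SCC(NC(=O)CCC(N)C(=O)O)C(=O)NCC(=O)O)[C@H](O)CCCC(=O)O)cc1` has hept-1-en-1-yl in place of hexyloxy on an aromatic carbon, para to a large group: hept-1-en-1-yl in place of hexyloxy on an aromatic carbon. Going by the values given here, one measured step bears on this change: a 3.4-fold higher number from compound 1 to compound 3 (0.54 log units; beyond the scatter), a modest step beyond the scatter, with hexyloxy in place of heptyl. Going by these compounds, the entering group, like the heptyl of compound 1 at 74.5 nM, is carbon only, although its double bond remains untested. A modest step toward a lower number is therefore expected, a 2.0-fold lower number from compound 3 to compound 4 (0.29 log units; within the scatter). The estimated value for compound 4 is 130 nM, with an expected range from 45 nM to 380 nM.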

Compound 4, half-maximal effective concentration: 451 nM
Beside the measured number, compound 4's estimate is 3.5-fold (0.54 log units) below it; measured number above the stated range.
By their numbers in this assay, from the lowest: compound 1; then compounds 3 and 4 (each within the scatter of the next); then compound 2.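

In this assay, hept-1-en-1-yl in place of hexyloxy on this aromatic carbon gives a 1.8-fold higher number from compound 3 to compound 4 (0.25 log units; within the scatter), so the oxygen-bearing and the all-carbon chain cannot be told apart here. Set against heptyl, the same group gives a 6.1-fold higher number from compound 1 to compound 4 (0.78 log units; beyond the scatter), which shows that a carbon-only chain at this place is not enough and that the double bond outside the ring marks the difference in this pair. Nothing measured here explains either step. Going by these compounds, it remains open how a longer chain such as nonyl, or an amine in place of heptyl, would read at this place.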